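A few compounds are considered here, and "the series" means these few. Any claim that something is new, unique, unknown or untested is made for them only; others in the source may bear on it.

In a functional assay on SK-MEL-5 cells (Homo sapiens) for cytotoxicity (a lower number here means that less compound is needed, a higher number that more compound is needed for the effect), compound 1 `COc1cc(/C=C/c2ccc(SC)cc2)cc(OC)c1OC` gives 2.8 uM. Compound 2 `COc1cc(/C=C/c2ccc(C(C)(C)C)cc2)cc(OC)c1OC` gives > 25 uM, which is a limit of the assay and not a number. Compound 3 `CCCOc1ccc(/C=C/c2cc(OC)c(OC)c(OC)c2)cc1` has propoxy in place of tert-butyl on an aromatic carbon, para to a large group (propoxy in place of tert-butyl on an aromatic carbon). For the measured compounds named here, only one measured step bears on this change: an at least 8.9-fold higher number from compound 1 to compound 2 (0.95 log units; beyond the scatter), with tert-butyl in place of methylsulfanyl on an aromatic carbon. Read in reverse, that step suggests that removing tert-butyl may lower the number in this assay. However, propoxy is not methylsulfanyl, and the size of that step is known only against a limit, so only part of it is expected to return. The expected change is an at least 2.7-fold lower number from compound 2 to compound 3 (0.44 log units; beyond the scatter), a moderate move towards a lower number. For compound 3 the estimate is 9 uM, with an expected range from 2.5 uM to 30 uM.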

Compound 3, concentration for half-maximal effect: > 25 uM
Compound 3 was reported as a limit; the forecaster's own chance of this, stated with the estimate: 30%; at least 2.7-fold (0.44 log units) between middle value and limit.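

In this assay the change to propoxy gives an at least 8.9-fold higher number from compound 1 to compound 3 (0.95 log units; beyond the scatter), so a second group at this place, after tert-butyl, fails to keep the value of compound 1. Compound 3 gives > 25 uM, which is a limit of the assay and not a number. The step between compound 2 and compound 3 cannot be read, and the two groups cannot be ranked against each other: the limit of > 25 uM in this assay, at which 2 of the 3 values shown sit.

As far as these compounds go, how far beyond that limit compound 2 and compound 3 truly lie remains open, so propoxy and tert-butyl may or may not differ. Also open, from the compounds shown here alone, is whether the value of compound 1 is tied to methylsulfanyl alone or would hold with methoxy, ethylsulfanyl or a dimethylamino group at this place.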